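The source may report more compounds than this note shows. Statements on the series, on what has been measured and on what is new or still open speak of the compounds shown alone.

Measured compounds:
compound 1, `CCCCCCCCCCOC(=O)CCC(=O)N1CCN(CCCOc2cc3c(Nc4ccc(F)c(Cl)c4)ncnc3cc2OC)CC1`, 15.5%
compound 2, `CCCCCCCCCCCCCCCCCCOC(=O)CCC(=O)N1CCN(CCCOc2cc3c(Nc4ccc(F)c(Cl)c4)ncnc3cc2OC)CC1`, 91%

In a functional assay on A549 cells (Homo sapiens) for cytotoxicity, read by MTT assay, with a stated time of 24 h, tested at 40 uM (on this read-out higher numbers stand for a weaker effect at the one concentration tested and lower numbers for a stronger effect), compound 1 gives 15.5%, and compound 2 gives 91%. Among the measured compounds shown here, compound 2 stands highest of the two numbers, with compound 1 as its only neighbour, a number 75.5 percentage points higher from compound 1 to compound 2 (beyond the scatter). That single step is the only one recorded, and it is the one that bears on what follows: an octyl group added to the ester chain moved the read-out far upward, beyond the scatter.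

Compound 3, `CCCCCCCCCCCCCCCCCCCCOC(=O)CCC(=O)N1CCN(CCCOc2cc3c(Nc4ccc(F)c(Cl)c4)ncnc3cc2OC)CC1`, carries a further lengthening of the same chain, (ethyl in place of hydrogen on a saturated chain carbon, ten or more bonds along the chain from an oxygen next to a carbonyl group). For the measured compounds named here, the one comparable step, a number 75.5 percentage points higher from compound 1 to compound 2 (beyond the scatter), was large, but it came from a much greater addition of chain; an ethyl group is a far smaller change, and compound 2 already lies close to the top of the scale in this assay. In this assay the expected step is therefore a number 2 percentage points higher from compound 2 to compound 3 (within the scatter), small enough to lie within the scatter. Compound 3 is estimated at 93%, with a range from 80% to 100%.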

Compound 3, a percentage reported as activity, at one concentration (the size of the read-out at that concentration, not a potency): 87.1%
Estimate against measurement, compound 3: 5.9 percentage points above, within the range that was stated.
By their numbers in this assay, from the lowest: compound 1; then compounds 3 and 2 (each within the scatter of the next).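

In this assay, among the compounds shown here, ethyl in place of hydrogen on a saturated chain carbon, ten or more bonds along the chain from an oxygen next to a carbonyl group, gives a number 3.9 percentage points lower from compound 2 to compound 3 (within the scatter), so compounds 2 and 3 cannot be told apart and the large move seen with the earlier octyl change has no counterpart here. The longer decyl difference gives a number 71.6 percentage points higher from compound 1 to compound 3 (beyond the scatter), a large step of the same kind as a number 75.5 percentage points higher from compound 1 to compound 2 (beyond the scatter), which means that both long-chain compounds stand well apart from compound 1 on this read-out. Nothing available on these compounds accounts for this behaviour of the chain.

The three compounds leave open where between compound 1 and compound 2 the read-out climbs, since a dodecyl or a tetradecyl chain at this position would be needed to show whether the rise is gradual or abrupt. They also leave open how the ester chain would behave if it carried an amine or a carboxylic acid in place of its plain saturated carbons.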